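Swapping the 3-acetylphenyl group of compound 2

A few compounds are considered here, and "the series" means these few. Any claim that something is new, unique, unknown or untested is made for them only; others in the source may bear on it.

In a functional assay on HCT-116 cells (Homo sapiens) for cytotoxicity, read by sulforhodamine B assay, with a stated time of 24 h (on this read-out lower numbers stand for stronger inhibition and higher numbers for weaker inhibition), compound 1 `O=C1Nc2ccc(S(=O)(=O)N3CCOCC3)cc2/C1=N/c1cccc(C(F)(F)F)c1` gives 15900 nM and compound 2 `CC(=O)c1cccc(/N=C2\C(=O)Nc3ccc(S(=O)(=O)N4CCOCC4)cc32)c1` gives 29000 nM as its reading. With acetyl in place of trifluoromethyl on an aromatic carbon, the data show a 1.8-fold higher number from compound 1 to compound 2 (0.26 log units; within the scatter) and so compound 2 stands level with compound 1. Among the compounds with values here, compound 3 `O=C1Nc2ccc(S(=O)(=O)N3CCOCC3)cc2/C1=N/NS(=O)(=O)c1ccccc1` has (phenylsulfonyl)amino in place of 3-acetylphenyl on a double-bonded nitrogen and this place has no measured step of its own. Within the data shown here, the one step available, a 1.8-fold higher number from compound 1 to compound 2 (0.26 log units; within the scatter) concerns a group on the aromatic ring that now leaves, so it bears only indirectly and offers no ground for a large shift. No change beyond the scatter is therefore expected in this assay and the expected step is a 1.5-fold lower number from compound 2 to compound 3 (0.16 log units; within the scatter) in the estimate. Compound 3 is estimated at 20000 nM with an expected range from 7000 nM to 55000 nM as its likely span.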

Compound 3, half-maximal inhibitory concentration: 13300 nM
Compound 3: middle estimate off by 1.5-fold (0.18 log units), on the high side, and the stated range covers the measured number.
By their numbers in this assay, from the lowest: compounds 3, 1 and 2 (each within the scatter of the next, the first and the last beyond it).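

In this assay, within the data shown here, the place on the double-bonded nitrogen now carries something other than a substituted phenyl group, and (phenylsulfonyl)amino in place of 3-acetylphenyl gives a 2.2-fold lower number from compound 2 to compound 3 (0.34 log units; beyond the scatter), the first modest step beyond the scatter in this set. The same group in place of 3-(trifluoromethyl)phenyl gives a 1.2-fold lower number from compound 1 to compound 3 (0.08 log units; within the scatter), so the change reads as a real step only against compound 2, and the place shows no general gain from this swap. No measurement at hand bears on why the two comparisons differ.

The compounds shown leave open whether the sulfonyl link or the phenyl ring at its end matters for the reading. An amine or a carboxylic acid on that ring, or a longer chain in its stead, would separate the two.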